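This account rests on a few compounds, and the source may have more. Where it says the series, first, only, none or still open, it means among the compounds named here.

Of the compounds shown here, three sharing a core have been tested in a functional assay on NCI-H661 cells (Homo sapiens) for antiproliferative activity, with a stated time of 48 h; on this read-out lower numbers stand for stronger inhibition and higher numbers for weaker inhibition. Compound 1 `CC1(CCCCC(=O)NO)Cc2ccccc2C1=O` gives > 25000 nM, which is a limit of the assay and not a number. Compound 2 `CC1(CCCCCCC(=O)Nc2ccccc2N)Cc2ccccc2C1=O` gives >= 25000 nM, and this too is only a limit. Among the compounds with values here, compound 3 `CC1(CCCCCC(=O)Nc2ccccc2N)Cc2ccccc2C1=O` gives 20000 nM, the one exact number among the three. Compound 2 therefore offers no exact value as a starting point, only the assay's limit.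

The unmeasured compound 4 `CC1(CCCCCCC(=O)NO)Cc2ccccc2C1=O` differs from compound 2 in one place: hydroxy in place of 2-aminophenyl on an amide-type nitrogen. Hydroxy takes the place of 2-aminophenyl on an amide-type nitrogen, so that (2-aminophenyl)amino becomes hydroxyamino. Within the data shown here, no pair of measured compounds shows this same change, so the data give no direct size for it. A modest move toward lower numbers is the expectation, and a result that again reaches only the limit would not be surprising. The estimated at least 3.1-fold lower number from compound 2 to compound 4 (0.49 log units; beyond the scatter) points toward stronger inhibition, but it is uncertain since it starts from a limit. For compound 4 the expected value in this assay is 8000 nM, with an estimated range from 1500 nM to 30000 nM.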

Compound 4, half-maximal inhibitory concentration: 20000 nM
Compound 4: middle estimate off by 2.5-fold (0.40 log units), on the low side; measured number inside the range.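

In this assay, within the data shown here, compound 4 gives 20000 nM, the first exact number for a compound carrying hydroxycarbamoyl, so this family can now be placed on the scale and not only at the edge of it. Hydroxy in place of 2-aminophenyl on the amide-type nitrogen gives an at least 1.2-fold lower number from compound 2 to compound 4 (0.09 log units; that floor lies within the scatter), and 2-(hydroxycarbamoyl)ethyl in place of hydroxycarbamoyl on the saturated chain carbon gives an at least 1.2-fold lower number from compound 1 to compound 4 (0.09 log units; that floor lies within the scatter); both are only floors, so neither establishes a real gain in inhibition. The true size of the hydroxy change stays unknown because compound 2 gives a limit of the assay and not a number: the limit of >= 25000 nM in this assay, at which 1 of the 4 values shown sits.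

Still open, from the compounds shown here alone, is how large either step really is, which would take exact numbers for compound 1 and compound 2 in this assay. Also open, going by these compounds, is whether a carboxylic acid in place of hydroxycarbamoyl, or a longer chain carrying hydroxycarbamoyl, would bring the number clearly down from that of compound 4.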